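A few compounds are considered here, and "the series" means these few. Any claim that something is new, unique, unknown or untested is made for them only; others in the source may bear on it.

In a functional assay on A549 cells (Homo sapiens) for inhibition, read by MTT assay, with a stated time of 96 h (on this read-out lower numbers stand for stronger inhibition of growth and higher numbers for weaker inhibition of growth), the measured compounds are:

compound 1, `C=CCOC(=O)SCCCCCCNC(=O)c1cc(-c2ccncc2)n[nH]1`: 15200 nM
compound 2, `CCCC(=O)SCCCCCCNC(=O)c1cc(-c2ccncc2)n[nH]1`: 15100 nM
compound 3, `CCCCCCCC/C=C\CCCCCCCC(=O)SCCCCCCNC(=O)c1cc(-c2ccncc2)n[nH]1`: 33300 nM

Compound 2 sits at the low end of these numbers, but compound 1 is within the scatter of it, and only compound 3 stands apart with a higher number. Compound 4, `CC(C)C(=O)SCCCCCCNC(=O)c1cc(-c2ccncc2)n[nH]1`, differs from compound 2 in one place: isopropyl in place of propyl on a carbonyl carbon. Within the data shown here, the one measured step at this place, a 1.0-fold lower number from compound 1 to compound 2 (0.00 log units; within the scatter), swapped the group on the carbonyl carbon without moving the number, which suggests this position tolerates such changes. The step to compound 4 is therefore expected to stay within the scatter, with no clear direction, so that compound 4 is estimated at 15000 nM, between 9000 nM and 26000 nM, meaning a 1.0-fold lower number from compound 2 to compound 4 (0.00 log units; within the scatter).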

Compound 4, concentration for 50% growth inhibition: 16800 nM
The estimate for compound 4 lay 1.1-fold (0.05 log units) below the measured number, within the range that was stated.
By their numbers in this assay, from the lowest: compounds 2, 1, 4 and 3 (each within the scatter of the next, the first and the last beyond it).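

In this assay, among these compounds, the branched isopropyl on the carbonyl carbon is not separated from the straight propyl, with a 1.1-fold higher number from compound 2 to compound 4 (0.05 log units; within the scatter), so branching at this place, which the earlier compounds did not test, leaves the number within the scatter. Isopropyl in place of allyloxy gives the same picture, with a 1.1-fold higher number from compound 1 to compound 4 (0.04 log units; within the scatter). Nothing available explains this lack of separation. The compounds shown leave open whether a phenyl ring, an amine or a carboxylic acid on this carbonyl carbon would move the number.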